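The source may report more compounds than this note shows. Statements on the series, on what has been measured and on what is new or still open speak of the compounds shown alone.

Compound 1 `COc1ccc2occ(CSC(=S)N3CCCCC3)c(=O)c2c1`: 930 nM
Compound 2 `O=c1cc(CSC(=S)N2CCCCC2)oc2cc(Cl)ccc12`: 3000 nM

Of the compounds shown here, two have so far been measured in a functional assay on MDA-MB-435S cells (Homo sapiens) for antiproliferative activity, read by MTT assay, with a stated time of 72 h; a lower number here means a stronger inhibitor, a higher number a weaker inhibitor. Compound 1 gives 930 nM, while compound 2 gives 3000 nM, the higher of the two numbers; the gap between them lies beyond the usual scatter, so compound 2 is the weaker inhibitor of the pair. Compound 3 `CCN(CC)C(=S)SCc1cc(=O)c2ccc(Cl)cc2o1` has not yet been measured. It differs from compound 2 in a single place: diethylamino in place of piperidin-1-yl on a thiocarbonyl carbon. The ring is opened into an open chain, and the thiocarbonyl carbon with its sulfur neighbour stays as it was. Within the data shown here, no measured pair shows what such a change does, so any expectation rests on how alike the two groups are. The step from compound 2 is expected to be small, no change at the digits printed from compound 2 to compound 3 (within the scatter), with no clear direction and probably within the scatter. Compound 3 is therefore estimated at 3000 nM, with a range from 1200 nM to 7500 nM.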

Compound 3, half-maximal inhibitory concentration: 23500 nM
Compound 3: middle estimate off by 7.8-fold (0.89 log units), on the low side; measured number above the stated range.
By their numbers in this assay, from the lowest: compound 1; then compound 2; then compound 3.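

In this assay, diethylamino in place of piperidin-1-yl on a thiocarbonyl carbon gives a 7.8-fold higher number from compound 2 to compound 3 (0.89 log units; beyond the scatter), so compound 3 is the weaker inhibitor of this pair. Among these compounds, this is the first comparison here in which only one place differs, and it shows that activity responds to the group on this carbon, even though the swap only opens a ring into an open chain. The thiocarbonyl carbon, its sulfur neighbour and the shared core stay the same, but no measurement shown explains the step.

The compounds shown leave open whether a smaller ring such as pyrrolidin-1-yl, a ring containing oxygen such as morpholin-4-yl, or a shorter chain such as dimethylamino would behave like piperidin-1-yl or like diethylamino. Going by these compounds, compound 1 differs from compound 2 in more than one place, so the effect of this change on the core of compound 1 also remains unknown.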